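Tert-butyl to morpholin-3-yl on the shared core

The compounds below may be only part of what the source reports. "The series", "measured", "known", "first", "only" and "open" are said of these compounds alone.

Measured in a functional assay on A-375 cells (Homo sapiens) for inhibition, read by MTT assay, with a stated time of 5 days; on this read-out higher numbers stand for weaker inhibition and lower numbers for stronger inhibition:
- compound 1 `Nc1nccc(-c2sc(C3CCCN3)nc2-c2cccc(NS(=O)(=O)c3cc(F)ccc3F)c2F)n1`: 11.2 nM
- compound 2 `CC(C)(C)c1nc(-c2cc(Cl)cc(NS(=O)(=O)c3cc(F)ccc3F)c2F)c(-c2ccnc(N)n2)s1`: 1.73 nM

Of these two compounds, compound 2 has the lower number, at 1.73 nM, and so the stronger inhibition in this assay. The gap to compound 1 lies beyond the scatter of the measurement.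

The next compound to be tested is compound 3 `Nc1nccc(-c2sc(C3COCCN3)nc2-c2cc(Cl)cc(NS(=O)(=O)c3cc(F)ccc3F)c2F)n1`. It has morpholin-3-yl in place of tert-butyl on an aromatic carbon, next to the ring nitrogen and next to the ring sulfur (morpholin-3-yl in place of tert-butyl on an aromatic carbon).

Among the compounds with values here, no measured pair isolates a change at this place, so the expectation rests on thin evidence. Compound 1 also bears a non-aromatic ring at this place and gives 11.2 nM, but it differs from compound 2 elsewhere as well. A move to a higher number, meaning weaker inhibition, is therefore expected, probably beyond the scatter. The expected change is a 5.2-fold higher number from compound 2 to compound 3 (0.72 log units; beyond the scatter). For compound 3 the estimated value is 9 nM, with an expected range of 2.5 nM to 30 nM.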

Compound 3, half-maximal inhibitory concentration: 2.06 nM
Beside the measured number, compound 3's estimate is 4.4-fold (0.64 log units) above it; measured number outside the range, below it.
By their numbers in this assay, from the lowest: compounds 2 and 3 (each within the scatter of the next); then compound 1.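

In this assay, morpholin-3-yl in place of tert-butyl on this aromatic carbon gives a 1.2-fold higher number from compound 2 to compound 3 (0.08 log units; within the scatter), the only step shown that isolates this position. Tert-butyl, with no ring and no hydrogen-bond donors or acceptors, and morpholin-3-yl, a larger six-membered non-aromatic ring that carries both donor and acceptors, therefore read alike here, so on this pair the read-out does not depend on which of the two groups occupies the position. No independent measurement bears on why these two groups read alike.

Compound 3 differs from compound 1 at this place and elsewhere on the shared core, so the value of compound 1, 11.2 nM, cannot be assigned to either difference alone. Also open, on these data alone, is how widely this position tolerates change in this assay: an open-chain amine, a carboxylic acid or a piperidin-2-yl ring, which would test the ring oxygen of morpholin-3-yl, might or might not stay within the scatter of compound 2.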